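Replacing the trifluoromethylphenyl on the carbonyl carbon

The compounds below may be only part of what the source reports. "The series", "measured", "known", "first", "only" and "open" are said of these compounds alone.

In a functional assay on HepG2 cells (Homo sapiens) for antiproliferative activity, read by MTT assay, with a stated time of 48 h (on this read-out lower numbers stand for stronger inhibition and higher numbers for weaker inhibition), compound 3 `COc1ccc(/C=C/c2cc(OC)cc(OC)c2/C=C/C(=O)c2ccc(C(F)(F)F)cc2)cc1` gives 18.7 ug/mL, the highest of the three numbers. Compound 2 `CCCCCCOc1ccc(C(=O)/C=C/c2c(/C=C/c3ccc(OC)cc3)cc(OC)cc2OC)cc1` gives 16.2 ug/mL, and the step of a 1.2-fold higher number from compound 2 to compound 3 (0.06 log units; within the scatter). Compound 1 `CCOc1ccc(C(=O)/C=C/c2c(/C=C/c3ccc(OC)cc3)cc(OC)cc2OC)cc1` gives 8 ug/mL, and the step of a 2.3-fold higher number from compound 1 to compound 3 (0.37 log units; beyond the scatter). Compound 4 `COc1ccc(/C=C/c2cc(OC)cc(OC)c2/C=C/C(=O)c2ccc(C)cc2C)cc1` differs from compound 3 by 2,4-dimethylphenyl in place of 4-(trifluoromethyl)phenyl on a carbonyl carbon. Both measured steps that alter the ring on the carbonyl carbon moved the number only modestly or not beyond the scatter, and neither introduces a dimethylphenyl, so the direction is uncertain. Compound 4 is therefore expected to show a 1.3-fold lower number from compound 3 to compound 4 (0.13 log units; within the scatter), a change that may stay within the scatter. Compound 4 is estimated at 14 ug/mL, with a range from 6 ug/mL to 30 ug/mL.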

Compound 4, half-maximal inhibitory concentration: 0.9 ug/mL
Estimate against measurement, compound 4: 16-fold (1.19 log units) above; the measured number lies below the stated range.
By their numbers in this assay, from the lowest: compound 4; then compound 1; then compounds 2 and 3 (each within the scatter of the next).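

In this assay, the ring on the carbonyl carbon proved able to carry a large change: 2,4-dimethylphenyl in place of 4-(trifluoromethyl)phenyl gives a 21-fold lower number from compound 3 to compound 4 (1.32 log units; beyond the scatter), and in place of 4-ethoxyphenyl it gives an 8.9-fold lower number from compound 1 to compound 4 (0.95 log units; beyond the scatter). The earlier compounds shown here, whose steps at this place stayed modest or within the scatter, showed no such reach. Nothing available here accounts for the drop. From the compounds shown here alone, whether a single methyl group would do as well as the two in 2,4-dimethylphenyl stays open. So does what an amine or a carboxylic acid on this ring would give.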